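Sulfonyl swap on a weakly active quinolone core

The compounds below may be only part of what the source reports. "The series", "measured", "known", "first", "only" and "open" are said of these compounds alone.

Compound 1 `COc1ccc(-c2cc(=O)c3c(OC)cc(OC)cc3[nH]2)cc1`: > 31100 nM in a functional assay on KOPN-8 cells (Homo sapiens) for antiproliferative activity, with a stated time of 72 h (on this read-out higher numbers stand for an effect only at larger amounts of compound and lower numbers for an effect already at smaller amounts), a limit of the assay.
Compound 2 `COc1ccc(-c2c(I)c(=O)c3c(OC)cc(OC)cc3n2S(=O)(=O)c2ccc(OC)cc2)cc1`: 8580 nM in this assay.
Compound 3 `COc1ccc(-c2cc(=O)c3c(OC)cc(OC)cc3n2S(=O)(=O)c2cccc([N+](=O)[O-])c2)cc1`: > 39600 nM in this assay, a limit of the assay.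

Of the compounds shown here, three sharing one core have been measured so far. Compound 2 is the only one to give a real number in this assay. Compound 1 gives only a limit of the assay. Compound 3 also gives only a limit of the assay, which means its true value is not known beyond the fact that it sits at the limit of > 39600 nM in this assay, at which 1 of the 3 values shown sits; no effect was seen at the amounts tested.

The next compound, compound 4 `COc1ccc(-c2cc(=O)c3c(OC)cc(OC)cc3n2S(=O)(=O)c2ccc(Br)s2)cc1`, keeps everything of compound 3 except the group on the sulfonyl sulfur: 5-bromothiophen-2-yl in place of 3-nitrophenyl on a sulfonyl sulfur.

No step between measured compounds is shown, so the size of this change can only be guessed. Within the data shown here, compound 3 sits at a limit and compound 1, without any sulfonyl group, sits at a limit too, while compound 2 with a different sulfonyl group and an added iodine is the only one with a number. For compound 4, a weak effect is therefore expected, with a good chance that this assay again reports only a limit; the estimated step from compound 3 is an at least 1.3-fold lower number from compound 3 to compound 4 (0.12 log units; that floor lies within the scatter). The estimate for compound 4 in this assay is 30000 nM, expected to lie between 8000 nM and 100000 nM.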

Compound 4, half-maximal effective concentration: > 48200 nM
Compound 4: a limit, no number; the forecaster's own chance of this, stated with the estimate: 55%; middle value at least 1.6-fold (0.20 log units) away from the limit.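

In this assay compound 4 gives > 48200 nM, a limit of the assay. Compound 1 and compound 3 also give only limits, so neither step to compound 4 can be read. As far as these compounds go, whether 5-bromothiophen-2-yl and 3-nitrophenyl on a sulfonyl sulfur differ at all in this assay stays open.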